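This account rests on a few compounds, and the source may have more. Where it says the series, first, only, none or still open, it means among the compounds named here.

In a functional assay on MIA PaCa-2 cells (Homo sapiens) for antiproliferative activity, read by sulforhodamine B assay, with a stated time of 48 h (on this read-out lower numbers stand for stronger inhibition of growth and higher numbers for weaker inhibition of growth), compound 1 `O=C(NCc1cn(Cc2ccc(Cl)cc2)nn1)c1cn(-c2ccccc2)nc1-c1ccccc1` gives 8700 nM, the second highest of the three numbers recorded. Compound 2 `O=C(NCc1cn(Cc2ccc(C(F)(F)F)cc2)nn1)c1cn(-c2ccccc2)nc1-c1ccccc1` gives 17700 nM, and compound 3 `COc1cc(Cn2cc(CNC(=O)c3cn(-c4ccccc4)nc3-c3ccccc3)nn2)cc(OC)c1OC` gives 1000 nM. The steps among them are a 2.0-fold higher number from compound 1 to compound 2 (0.31 log units; beyond the scatter), an 8.7-fold lower number from compound 1 to compound 3 (0.94 log units; beyond the scatter) and an 18-fold lower number from compound 2 to compound 3 (1.25 log units; beyond the scatter); every one of them alters the aryl group on the saturated chain carbon bound to an aromatic nitrogen, and none touches the phenyl on the shared core.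

Compound 4 `O=C(NCc1cn(Cc2ccc(Cl)cc2)nn1)c1cn(-c2ccccc2)nc1-c1ccc(F)cc1` differs from compound 1 by fluoro in place of hydrogen on an aromatic carbon, turning that phenyl into a 4-fluorophenyl at the carbon para to a large group. Among the compounds with values here, no measured step bears directly on this change; the three steps speak to a different part of the molecule, and what enters is a single fluorine with no ring, no donor and no acceptor. In this assay the expected step, a 1.1-fold lower number from compound 1 to compound 4 (0.04 log units; within the scatter), is therefore taken to stay within the scatter, in no firm direction. Compound 4 is estimated at 8000 nM, with a range from 3500 nM to 18000 nM.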

Compound 4, concentration for 50% growth inhibition: 280 nM
The estimate for compound 4 lay 29-fold (1.46 log units) above the measured number, and the stated range ends above it.
By their numbers in this assay, from the lowest: compound 4; then compound 3; then compound 1; then compound 2.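

In this assay, within the data shown here, the result shows that the shared core is not a silent part of the molecule: the earlier steps changed only the aryl group on the saturated chain carbon, whereas fluoro in place of hydrogen on that phenyl of the core gives a 31-fold lower number from compound 1 to compound 4 (1.49 log units; beyond the scatter) and so turns it into a 4-fluorophenyl. A single entering heavy atom, on an aromatic carbon para to a large group, here produces a larger step than any of the exchanges of whole aryl groups among compounds 1, 2 and 3. Nothing available explains this step.

On these data alone, it remains open whether the gain belongs to fluoro itself or would also follow from a methoxy group, an amine or a carboxylic acid on the same carbon. As far as these compounds go, it also remains open whether the same change would carry over to the 3,4,5-trimethoxyphenyl series of compound 3.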